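Moving from pyridin-2-yl to pyridin-3-yl: cytotoxicity expectation

The source may report more compounds than this note shows. Statements on the series, on what has been measured and on what is new or still open speak of the compounds shown alone.

Compound 1 `COc1cccc(S(=O)(=O)/C=C/c2ccccn2)c1` in an ADME assay on BV-2 cells (Mus musculus) for cytotoxicity, with a stated time of 24 h, tested at 10 uM (on this read-out higher numbers stand for a weaker effect at the one concentration tested and lower numbers for a stronger effect), gives 100%. Compound 2 `COc1cccc(S(=O)(=O)/C=C/c2cccc(Cl)n2)c1` gives 100% and compound 3 `COc1cccc(S(=O)(=O)/C=C/c2ncccc2Cl)c1` gives 100%, so compound 1 stands level with both. The two measured steps, no change at the digits printed from compound 1 to compound 2 (within the scatter) and no change at the digits printed from compound 1 to compound 3 (within the scatter), each put a chloro in place of a hydrogen and left the read-out unchanged. Compound 4 `COc1cccc(S(=O)(=O)/C=C/c2cccnc2)c1` differs from compound 1 by pyridin-3-yl in place of pyridin-2-yl on a double-bonded chain carbon bound to a double-bonded chain carbon. For the measured compounds named here, no measured step moves the ring attachment itself, so the chloro steps bear on it only loosely; every change seen so far, however, left the value flat, and no step beyond the scatter is expected in this assay. For compound 4 the expected step is no change at the digits printed from compound 1 to compound 4 (within the scatter). Compound 4 is therefore estimated at 100%, with a range from 88% to 100%.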

Compound 4, a percentage reported as activity, at one concentration (the size of the read-out at that concentration, not a potency): 100%
Compound 4: middle estimate and measured number agree at the digits printed, within the range that was stated.
By their numbers in this assay, from the lowest: compounds 1, 2, 3 and 4 (each within the scatter of the next).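

In this assay, pyridin-3-yl in place of pyridin-2-yl gives no change at the digits printed from compound 1 to compound 4 (within the scatter) and thus adds a change of ring attachment to the chloro replacements already read. At this place, on a double-bonded chain carbon bound to a double-bonded chain carbon, the two pyridine attachments cannot be told apart by this read-out. No evidence on the reason for this is available.

Going by these compounds, what an amine or a carboxylic acid on the pyridine ring would do to the read-out stays open. So does whether any change to the shared core moves it beyond the scatter.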